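Bromo in place of methoxy on the amide aryl ring

The compounds below may be only part of what the source reports. "The series", "measured", "known", "first", "only" and "open" are said of these compounds alone.

In a physicochemical assay for lipophilicity, read by mass spectrometry (on this read-out lower numbers stand for lower lipophilicity and higher numbers for higher lipophilicity), compound 1 `COc1cc2c(cc1OC)C(=O)C(C(=O)Nc1ccc(F)cc1)C2` gives 2.36 and compound 2 `COc1cccc(NC(=O)C2Cc3cc(OC)c(OC)cc3C2=O)c1` gives 2.08 so the two stand within the scatter of each other. Compound 3 `COc1cc2c(cc1OC)C(=O)C(C(=O)Nc1cccc(Br)c1)C2` differs from compound 2 by bromo in place of methoxy on an aromatic carbon with bromo in place of methoxy on an aromatic carbon. Within the data shown here, only a number 0.28 log units lower from compound 1 to compound 2 (within the scatter) bears on this change, with 3-methoxyphenyl replacing 4-fluorophenyl, and it involves no bromo compound. A step up in this assay somewhat beyond the scatter is expected, though the data so far do not fix its size. a number 0.72 log units higher from compound 2 to compound 3 (beyond the scatter) is the estimated step. Compound 3 is expected at 2.8 with 2.4 and 3.2 as the estimated ends of its range.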

Compound 3, partition coefficient: 3.03
For compound 3 the middle estimate is 0.23 log units below the measured one, and the stated range covers the measured number.
By their numbers in this assay, from the lowest: compounds 2 and 1 (each within the scatter of the next); then compound 3.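

In this assay the change of bromo in place of methoxy on an aromatic carbon, meta to a large group, gives a step beyond the scatter (a number 0.95 log units higher from compound 2 to compound 3 (beyond the scatter)), whereas compound 1 and compound 2 stand within the scatter of each other. The 3-bromophenyl also separates from the 4-fluorophenyl on the amide-type nitrogen (a number 0.67 log units higher from compound 1 to compound 3 (beyond the scatter)). Nothing measured here accounts for the size of these steps.

The compounds shown leave open how an amine or a carboxylic acid on this aromatic carbon would read in this assay. Going by these compounds, whether bromo on another carbon of this ring gives a similar step also remains open.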